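The source may report more compounds than this note shows. Statements on the series, on what has been measured and on what is new or still open speak of the compounds shown alone.

Of the compounds shown here, three built on the same thio-sugar core have been tested in a functional assay on CCRF-HSB-2 cells (Homo sapiens) for antiproliferative activity; on this read-out higher numbers stand for weaker inhibition and lower numbers for stronger inhibition. Compound 1, `O=c1[nH]c(=O)n([C@H]2S[C@H](CO)[C@@H](O)[C@@H]2O)cc1/C=C/Cl`, gives > 100 ug/mL, which is a limit of the assay rather than a measured number. Compound 2, `Cc1cn([C@@H]2S[C@H](CO)[C@@H](O)[C@@H]2O)c(=O)[nH]c1=O`, gives > 100 ug/mL, again a limit and not a number. Compound 3, `Nc1ncnc2c1ncn2[C@@H]1S[C@H](CO)[C@@H](O)[C@@H]1O`, gives 14.8 ug/mL. Compound 2 thus stands at the limit of > 100 ug/mL in this assay, at which 2 of the 3 values shown sit, and nothing more can be read from its result than that it did not reach a number.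

Compound 4, `O=c1[nH]c(=O)n([C@@H]2S[C@H](CO)[C@@H](O)[C@@H]2O)cc1/C=C/Br`, differs from compound 2 by 2-bromoethenyl in place of methyl on an aromatic carbon. Within the data shown here, no step between two measured compounds differing in one place is available, so the size of this change cannot be taken from a measured pair. The measured compound most like compound 4 is compound 1, which also sits at the limit > 100 ug/mL. The step that the limit leaves unreadable from compound 2 to compound 4 is therefore expected to be none beyond the usual scatter. Compound 4 is expected to give about 150 ug/mL, between 40 ug/mL and 500 ug/mL, most likely reported only as a limit.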

Compound 4, half-maximal inhibitory concentration: > 100 ug/mL
Compound 4: a limit, no number (the forecaster's own chance of this, stated with the estimate: 75%); the middle value is on the limit's open side.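

Compound 2 and compound 4 both stop at a limit in this assay rather than at a number, and the step between them cannot be read. The compounds shown leave open whether 2-bromoethenyl in place of methyl on an aromatic carbon changes the inhibition at all, and by how much.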